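A few compounds are considered here, and "the series" means these few. Any claim that something is new, unique, unknown or untested is made for them only; others in the source may bear on it.

Compound 1 `O=C(Nc1cc2ncncc2cc1OCc1ccc(Cl)cc1)Nc1cccc2ccccc12`: > 10000 nM
Compound 2 `O=C(Nc1cccc(F)c1)Nc1cc2ncncc2cc1OCc1ccccc1Cl`: 9400 nM

Among the compounds with values here, in an ADME assay on cells (Astrocyte, Homo sapiens) for cytotoxicity, read by WST assay, with a stated time of 72 h (a lower number here means a stronger inhibitor, a higher number a weaker inhibitor), compound 2 gives 9400 nM, the only actual number so far. Compound 1 reads > 10000 nM, which is a limit of the assay and not a number. Compound 3 `O=C(Nc1cc2ncncc2cc1OCc1ccccc1Cl)Nc1cccc2ccccc12` has not been measured. It carries naphthalen-1-yl in place of 3-fluorophenyl on an amide-type nitrogen. Within the data shown here, compound 1 carries naphthalen-1-yl too, but no measured pair isolates this change. In this assay, a shift beyond the scatter is therefore not expected in either direction, and the estimated change is a 1.1-fold higher number from compound 2 to compound 3 (0.03 log units; within the scatter). For compound 3 the expected value is 10000 nM, with an estimated range of 5000 nM to 20000 nM.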

Compound 3, half-maximal inhibitory concentration: 2300 nM
The estimate for compound 3 lay 4.3-fold (0.64 log units) above the measured number, outside the stated range (below it).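

In this assay, naphthalen-1-yl in place of 3-fluorophenyl on an amide-type nitrogen gives a 4.1-fold lower number from compound 2 to compound 3 (0.61 log units; beyond the scatter), which shows that the number responds to the group at this position. With naphthalen-1-yl kept, 2-chlorophenyl in place of 4-chlorophenyl on a saturated chain carbon bound to an oxygen on an aromatic ring gives an at least 4.3-fold lower number from compound 1 to compound 3 (0.63 log units; beyond the scatter), so a second place matters as well. Compound 1 reads > 10000 nM, which is a limit of the assay and not a number: the limit of > 10000 nM in this assay, at which 1 of the 3 values shown sits.

On these data alone, whether a plain phenyl or a cyclohexyl on that nitrogen would also lower the number remains open. So does whether the naphthalen-1-yl step would have the same size with 4-chlorophenyl on the chain carbon.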